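Shortening the chain and simplifying the amine

The source may hold more compounds than are shown below. What is called first, only, known or untested is meant among the compounds shown, and "the series" means these compounds.

Compound 1, `O=C1c2c[n+]([O-])c3ccccc3c2C(=O)c2[nH]c3ccccc3c21`, gives 660 nM.
Compound 2, `CN(C)CCCCn1c2c(c3ccccc31)C(=O)c1c[n+]([O-])c3ccccc3c1C2=O`, gives 470 nM.
Compound 3, `CN1CCN(CCCCn2c3c(c4ccccc42)C(=O)c2c[n+]([O-])c4ccccc4c2C3=O)CC1`, gives 30 nM.

These values come from a functional assay on A-375 cells (Homo sapiens) for cytotoxicity, read by MTT assay, with a stated time of 72 h; a higher number here means a weaker inhibitor, a lower number a stronger inhibitor. Compound 3 has the lowest number of the three: the steps of a 22-fold lower number from compound 1 to compound 3 (1.34 log units; beyond the scatter) and a 16-fold lower number from compound 2 to compound 3 (1.19 log units; beyond the scatter) are both large and beyond the scatter, whereas a 1.4-fold lower number from compound 1 to compound 2 (0.15 log units; within the scatter) is within it. Compound 4, `O=C1c2c[n+]([O-])c3ccccc3c2C(=O)c2c1c1ccccc1n2CCN1CCCCC1`, has not yet been measured in this assay. It differs from compound 3 in one place. piperidin-1-yl in place of 2-(4-methylpiperazin-1-yl)ethyl on a saturated chain carbon, two bonds along the chain from an aromatic nitrogen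

For the measured compounds named here, only one measured step bears on this change: the step of a 16-fold lower number from compound 2 to compound 3 (1.19 log units; beyond the scatter), in which an amine carrying a single nitrogen was exchanged for a 4-methylpiperazin-1-yl group and the number fell strongly. Going by the values given here, compound 4 returns to a ring amine with one nitrogen, so that gain may be partly lost; no measured pair speaks to the shorter chain. Compound 4 is therefore expected to show a step of a 10-fold higher number from compound 3 to compound 4 (1.00 log units; beyond the scatter), a higher number than compound 3. Compound 4 is estimated at 300 nM, with a range from 80 nM to 1200 nM.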

Compound 4, half-maximal inhibitory concentration: 180 nM
For compound 4 the middle estimate is 1.7-fold (0.22 log units) above the measured one; measured number inside the range.
By their numbers in this assay, from the lowest: compound 3; then compound 4; then compounds 2 and 1 (each within the scatter of the next).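

In this assay, adding the 2-(piperidin-1-yl)ethyl chain on the aromatic nitrogen gives a real gain over the unsubstituted core (a 3.7-fold lower number from compound 1 to compound 4 (0.56 log units; beyond the scatter)), whereas the 4-(dimethylamino)butyl chain of compound 2 gave a change within the scatter. The piperidine chain also beats that dimethylamino chain (a 2.6-fold lower number from compound 2 to compound 4 (0.42 log units; beyond the scatter)), so the large gain is not confined to the 4-methylpiperazin-1-yl group. Even so, it does not match the 4-(4-methylpiperazin-1-yl)butyl chain (a 6.0-fold higher number from compound 3 to compound 4 (0.78 log units; beyond the scatter)), which keeps the lowest number of the four compounds.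

Amine and chain length change together in these steps, so a 4-(piperidin-1-yl)butyl chain or a 2-(4-methylpiperazin-1-yl)ethyl chain would be needed to tell their contributions apart. No available evidence explains the size of these steps.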